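The source may hold more compounds than are shown below. What is called first, only, known or untested is meant among the compounds shown, and "the series" means these compounds.

Measured in an ADME assay on L02 cells (Homo sapiens) for antiproliferative activity, read by MTT assay, with a stated time of 48 h; a higher number here means a weaker inhibitor, a lower number a stronger inhibitor:
Compound 1 `C#CCCOC(=O)c1ccc(C(CC)(CC)c2ccc(OCCC(O)(CC)CC)c(C)c2)n1CC`: > 50000 nM
Compound 2 `CCOC(=O)C(CC(=O)OC)NC(=O)c1ccc(C(CC)(CC)c2ccc(OCCC(O)(CC)CC)c(C)c2)n1CC`: 4280 nM

Compound 1 has only a limit of the assay, > 50000 nM, and no actual number. Within the data shown here, compound 2, at 4280 nM, therefore holds the only actual number in this assay. Compound 3 `CCC(C)C(NC(=O)c1ccc(C(CC)(CC)c2ccc(OCCC(O)(CC)CC)c(C)c2)n1CC)C(=O)O` has not yet been measured. It differs from compound 2 on the amide-type nitrogen: a group of 8 heavy atoms (6 carbon, 2 oxygen; no ring) in place of a group of 11 heavy atoms (7 carbon, 4 oxygen; no ring), on an amide-type nitrogen. The 1-carboxy-2-methylbutyl group takes the place of the larger group there.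

Among the measured compounds shown here, only one measured step bears on this change, and only in part. That step, an at least 11-fold lower number from compound 1 to compound 2 (1.06 log units; beyond the scatter), is large, and it replaced a smaller group on the carbonyl carbon with the larger one carrying the amide-type nitrogen. For the measured compounds named here, compound 3 keeps that nitrogen but carries a smaller group on it, and no measured step varies this group directly. A moderate move towards a higher number in this assay is therefore expected, though with wide uncertainty and a real chance of reaching the limit. The estimate amounts to an expected 3.3-fold higher number from compound 2 to compound 3 (0.51 log units; beyond the scatter). For compound 3 the expected value is 14000 nM, with an estimated range of 3500 nM to 50000 nM.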

Compound 3, half-maximal inhibitory concentration: 9990 nM
For compound 3 the middle estimate is 1.4-fold (0.15 log units) above the measured one, and the stated range covers the measured number.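

In this assay, the change on the amide-type nitrogen gives a 2.3-fold higher number from compound 2 to compound 3 (0.37 log units; beyond the scatter) and leaves a measured number rather than a limit, so this position accepts two quite different groups, one with its ester carbonyls and the 1-carboxy-2-methylbutyl group with its free carboxylic acid, at a modest cost. The change on the carbonyl carbon, with (1-carboxy-2-methylbutyl)amino in place of (but-3-yn-1-yl)oxy, gives an at least 5.0-fold lower number from compound 1 to compound 3 (0.69 log units; beyond the scatter), so a second compound carrying the amide-type nitrogen lies on the lower side of compound 1. The size of that step remains a lower bound, and the reading of it rests on a single limit: the limit of > 50000 nM in this assay, at which 1 of the 3 values shown sits.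

The two groups on the nitrogen differ in several ways at once, so the compounds shown do not separate the part played by the carboxylic acid from that of the branched chain, as the methyl ester of the compound 3 group would. As far as these compounds go, how a simple methyl group, a longer unbranched chain or a basic amine on that nitrogen would read in this assay also remains open.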